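This account rests on a few compounds, and the source may have more. Where it says the series, first, only, none or still open, it means among the compounds named here.

- compound 1 `CC/C(=C(/c1ccc(/C=C/C(=O)O)cc1)c1ccc(O)nc1)c1ccccc1` gives "not determined" (no result reported)
- compound 2 `CC/C(=C(/c1ccc(/C=C/C(=O)O)cc1)c1ccc2[nH]ccc2c1)c1ccccc1` gives 9 nM
- compound 3 `CC/C(=C(/c1ccc(/C=C/C(=O)O)cc1)c1ccc2[nH]ncc2c1)c1ccc(C#N)cc1` gives 47 nM

Among the measured compounds shown here, all results come from a functional assay on MCF7 cells (Homo sapiens) for cytotoxicity, read by CellTiter-Glo, with a stated time of 5 days (on this read-out higher numbers stand for weaker inhibition and lower numbers for stronger inhibition), and only two of them are numbers. Of these, compound 3 at 47 nM has the higher number, and so the weaker inhibition. Compound 2 sits at 9 nM and the gap between the two lies beyond the scatter.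

Compound 4 `CC/C(=C(/c1ccc(/C=C/C(=O)O)cc1)c1ccc2[nH]ncc2c1)c1ccc(C#N)cc1Cl` departs from compound 3 by chloro in place of hydrogen on an aromatic carbon in a single place, with chloro in place of hydrogen on an aromatic carbon, so that 4-cyanophenyl becomes 2-chloro-4-cyanophenyl. For the measured compounds named here, no measured pair isolates this change, so the direction is a judgement and the range stays wide. Compound 2 at 9 nM shows that this series reaches lower numbers, leaving room below compound 3 in this assay. A modest move toward stronger inhibition, only slightly beyond the scatter, is expected. The estimated step is a 2.4-fold lower number from compound 3 to compound 4 (0.37 log units; beyond the scatter) in this direction. For compound 4 the expected value is 20 nM (estimated range 6 nM to 60 nM).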

Compound 4, half-maximal inhibitory concentration: 4 nM
Estimate against measurement, compound 4: 5.0-fold (0.70 log units) above, outside the stated range (below it).
By their numbers in this assay, from the lowest: compound 4; then compound 2; then compound 3.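

In this assay, among the compounds shown here, the change from 4-cyanophenyl to 2-chloro-4-cyanophenyl gives a 12-fold lower number from compound 3 to compound 4 (1.07 log units; beyond the scatter) and is the first single-place step. It shows that this position, ortho to a large group and meta to a cyano group, accepts chloro and that one added heavy atom, with no ring, no hydrogen-bond donor or acceptor and no net charge, is enough for a large move toward stronger inhibition. No measurement available here explains this step.

Open, from the compounds shown here alone, is whether the step is specific to chloro or would also appear with fluoro, methyl or methoxy at the same place. Also open, going by these compounds, is whether chloro gives a step of similar size on the phenyl ring of compound 2, which carries no cyano group.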